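The source may hold more compounds than are shown below. What is called first, only, known or untested is meant among the compounds shown, and "the series" means these compounds.

Values in a physicochemical assay for solubility, at pH 7.4; on this read-out higher numbers stand for higher solubility and lower numbers for lower solubility:
- compound 1 `Cc1cc(NC(=O)Nc2ccc(C(C)(C)C)cc2)c2ccccc2n1`: 6200 nM
- compound 2 `Cc1cc(NC(=O)Nc2ccc(F)cc2)c2ccccc2n1`: 3700 nM
- compound 3 `Cc1cc(NC(=O)Nc2ccc(C(N)=O)cc2)c2ccccc2n1`: 900 nM

Compound 3 stands lowest of the three in this assay, and its gaps to both of the others are beyond the scatter. The next compound is compound 4 `Cc1cc(NC(=O)Nc2ccc(SC(F)(F)F)cc2)c2ccccc2n1`, not yet measured, with (trifluoromethyl)sulfanyl in place of carbamoyl on an aromatic carbon.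

Among the measured compounds shown here, no measured step has carbamoyl leaving, so the nearest evidence is the two steps in which it enters, read in reverse. These are a 6.9-fold lower number from compound 1 to compound 3 (0.84 log units; beyond the scatter) and a 4.1-fold lower number from compound 2 to compound 3 (0.61 log units; beyond the scatter), both modest. The step between the two groups other than carbamoyl, a 1.7-fold lower number from compound 1 to compound 2 (0.22 log units; within the scatter), lies within the scatter. For the measured compounds named here, this reading rests on only two groups, and neither is the incoming one, so the behaviour of (trifluoromethyl)sulfanyl itself remains untested here.

A modest rise is therefore expected, opposite in direction to the two steps in which carbamoyl enters. The expected step is a 3.9-fold higher number from compound 3 to compound 4 (0.59 log units; beyond the scatter). Compound 4 is estimated at 3500 nM, with an expected range of 1300 nM to 8000 nM.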

Compound 4, solubility: 200 nM
The estimate for compound 4 lay 18-fold (1.24 log units) above the measured number; measured number outside the range, below it.
By their numbers in this assay, from the lowest: compound 4; then compound 3; then compounds 2 and 1 (each within the scatter of the next).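

At this position, on an aromatic carbon para to a large group, carbamoyl does not mark the floor of the series in this assay: the change to (trifluoromethyl)sulfanyl gives a 4.5-fold lower number from compound 3 to compound 4 (0.65 log units; beyond the scatter), so taking carbamoyl away does not by itself restore the number. The gaps to the other two groups are wider, at a 19-fold lower number from compound 2 to compound 4 (1.27 log units; beyond the scatter) and a 31-fold lower number from compound 1 to compound 4 (1.49 log units; beyond the scatter), whereas fluoro and tert-butyl lie within the scatter of each other, so this one position spans a much larger range than the first three compounds showed. Nothing available bears on the cause of this drop.

Still open, going by these compounds, is whether an amine, a carboxylic acid, a nitrile or a longer alkyl chain at this position would fall with compound 4 or stay with compound 1 and compound 2. All four compounds also share one core, and whether the same order of groups holds on a different core remains an open question.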